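A tert-butyl swap on the one measurable compound

The source may report more compounds than this note shows. Statements on the series, on what has been measured and on what is new or still open speak of the compounds shown alone.

For the measured compounds named here, in a functional assay on A549 cells (Homo sapiens) for antiproliferative activity, read by MTT assay, with a stated time of 72 h (a higher number here means a weaker inhibitor, a lower number a stronger inhibitor), compound 2 (`O=C1O[C@H]([C@@H](O)Cn2cc(-c3ccc(Br)cc3)nn2)C(OCc2ccccc2)=C1OCc1ccccc1`) gives 750 nM as the only true number so far. Compound 1 (`O=C1O/C(=C\Cn2cc(-c3ccc(Br)cc3)nn2)C(OCc2ccccc2)=C1OCc1ccccc1`) stands at > 100000 nM as a limit of the assay. Compound 3 (`COc1ccc(-c2cn(C/C=C3\OC(=O)C(OCc4ccccc4)=C3OCc3ccccc3)nn2)cc1`) stands at > 100000 nM as a limit too. Going by the values given here, both share that ceiling (the limit of > 100000 nM in this assay, at which 2 of the 3 values shown sit), so the single measured step, methoxy in place of bromo (a step that the two limits leave unreadable from compound 1 to compound 3), has no readable size and offers no guide.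

Compound 4 (`CC(C)(C)c1cn(C[C@H](O)[C@H]2OC(=O)C(OCc3ccccc3)=C2OCc2ccccc2)nn1`) has tert-butyl in place of 4-bromophenyl on an aromatic carbon, which removes the six-membered aromatic ring of that group. Among the compounds with values here, compound 2 reaches 750 nM with this ring in place, and no measured compound lacks a ring there, although compounds 1 and 3 show that the ring alone does not secure a number. A loss of strength in this assay is therefore expected, but only tentatively. The expected change is a 4.0-fold higher number from compound 2 to compound 4 (0.60 log units; beyond the scatter) ( an estimate, toward weaker inhibition ). For compound 4 the estimated value is 3000 nM ( expected range 500 nM to 30000 nM).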

Compound 4, half-maximal inhibitory concentration: 34000 nM
Beside the measured number, compound 4's estimate is 11-fold (1.05 log units) below it, outside the stated range (above it).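

In this assay, for the compounds shown here, tert-butyl in place of 4-bromophenyl brings a 45-fold higher number from compound 2 to compound 4 (1.66 log units; beyond the scatter), the first step at this aromatic carbon whose size can be read. With the rest of the structure unchanged, the group on this carbon clearly has a strong hold on the read-out, and the ring of 4-bromophenyl goes with the stronger result in this pair. Compound 4 still gives a true number without any ring on this carbon, so a ring there is not required for a measurable result, and it stays clear of the ceiling: the limit of > 100000 nM in this assay, at which 2 of the 4 values shown sit.

This pair does not separate the loss of the ring from the loss of the bromine, since both leave together. A plain phenyl group or a cyclohexyl group on this carbon would begin to pull those two apart, and an amine on the ring would test a different kind of group there.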